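This account rests on a few compounds, and the source may have more. Where it says the series, first, only, none or still open, it means among the compounds named here.

Measured in a functional assay on the whole organism for inhibition, with Cavia porcellus as the target; a lower number here means that less compound is needed, a higher number that more compound is needed for the effect
Compound 1 `C=CCCn1c(=O)c2[nH]cnc2n(CCC)c1=O` gives 1.84 mg/kg
Compound 2 `CCCn1cnc2c1c(=O)n(C)c(=O)n2CCC` gives 27.5 mg/kg

Compound 2 at 27.5 mg/kg carries the higher of the two numbers, and its gap to compound 1 lies beyond the scatter. These two compounds differ in more than one place, so no single change can be read from them. Compound 3 `CCCn1c(=O)n(C)c(=O)c2c1ncn2CC(C)=O` has yet to be tested in this assay and departs from compound 2 in one place only. On a saturated chain carbon bound to an aromatic nitrogen, acetyl stands in place of ethyl (acetyl in place of ethyl on a saturated chain carbon bound to an aromatic nitrogen) so that propyl becomes 2-oxopropyl. Among the compounds with values here, no measured pair shows this change, so the expectation remains loose. Taking compound 2 at 27.5 mg/kg as the starting point, a modest shift toward a lower number is expected, and it may well stay within the scatter. The estimated change is a 1.8-fold lower number from compound 2 to compound 3 (0.26 log units; within the scatter) in that direction. For compound 3 the expected value is 15 mg/kg with an estimated range from 5 mg/kg to 50 mg/kg as its bounds.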

Compound 3, dose for half-maximal effect: 1.49 mg/kg
Compound 3: the middle estimate sits 10-fold (1.00 log units) above what was measured; measured number below the stated range.
By their numbers in this assay, from the lowest: compounds 3 and 1 (each within the scatter of the next); then compound 2.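

In this assay, within the data shown here, replacing propyl with 2-oxopropyl on a saturated chain carbon bound to an aromatic nitrogen gives an 18-fold lower number from compound 2 to compound 3 (1.27 log units; beyond the scatter), the first step that can be tied to a change in one place. It shows that this position is not indifferent to what it carries: exchanging the terminal ethyl for acetyl, which adds a double bond outside aromatic rings and a hydrogen-bond acceptor while leaving the net charge unchanged, moves the number well beyond the scatter. Nothing available explains why this single change has so large an effect on the result.

The compounds shown leave open whether the carbonyl itself is needed at this place, or whether a 2-hydroxypropyl chain, a 2-aminopropyl chain or a longer ketone chain such as 2-oxobutyl would also give a low number. Among these compounds, with this change seen in only one pair, they also leave open whether it would give a step of similar size with other groups elsewhere on the shared core.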